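From Aryl to Ester on a Sulfonamide Nitrogen

The compounds below may be only part of what the source reports. "The series", "measured", "known", "first", "only" and "open" are said of these compounds alone.

In a functional assay on RCC4 cells (Homo sapiens) for antiproliferative activity, read by XTT assay, with a stated time of 48 h (a lower number here means a stronger inhibitor, a higher number a weaker inhibitor), compound 1 `CC(=O)OC[C@H]1O[C@@H](n2cc(CN(c3ccccc3)S(=O)(=O)c3ccccc3)nn2)[C@H](OC(C)=O)[C@@H]1OC(C)=O` gives 150000 nM, compound 2 `COc1cccc(N(Cc2cn([C@@H]3O[C@H](COC(C)=O)[C@@H](OC(C)=O)[C@H](OC(C)=O)[C@H]3OC(C)=O)nn2)S(C)(=O)=O)c1` gives 200000 nM and compound 3 `CC(=O)OC[C@H]1O[C@@H](n2cc(CN(c3ccc(C#N)cc3)S(C)(=O)=O)nn2)[C@H](OC(C)=O)[C@@H](OC(C)=O)[C@@H]1OC(C)=O` gives 120000 nM, which places compound 3 within the scatter of both others. Compound 4 `COC(=O)C(C)(C)N(Cc1cn([C@@H]2O[C@H](COC(C)=O)[C@@H](OC(C)=O)[C@H](OC(C)=O)[C@H]2OC(C)=O)nn1)S(C)(=O)=O` differs from compound 3 by 1-(methoxycarbonyl)-1-methylethyl in place of 4-cyanophenyl on a sulfonamide nitrogen. Going by the values given here, only one measured step bears on this change: a 1.7-fold lower number from compound 2 to compound 3 (0.22 log units; within the scatter), an exchange of one aromatic substituent for another on a sulfonamide nitrogen. Among the compounds with values here, no measured compound shows a substituent without a ring at this place, so the evidence is indirect, and no step beyond the scatter is expected in this assay. Compound 4 is estimated at 150000 nM, with an expected range of 70000 nM to 300000 nM. This estimate means an expected 1.3-fold higher number from compound 3 to compound 4 (0.10 log units; within the scatter).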

Compound 4, half-maximal inhibitory concentration: 240000 nM
For compound 4 the middle estimate is 1.6-fold (0.20 log units) below the measured one, within the range that was stated.
By their numbers in this assay, from the lowest: compounds 3, 1, 2 and 4 (each within the scatter of the next).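

Placing 1-(methoxycarbonyl)-1-methylethyl on the sulfonamide nitrogen in this assay gives a 2.0-fold higher number from compound 3 to compound 4 (0.30 log units; within the scatter), and against the 3-methoxyphenyl compound it gives a 1.2-fold higher number from compound 2 to compound 4 (0.08 log units; within the scatter). Going by these compounds alone, this is the first substituent without a ring at this place, and the number stays within the scatter of both aryl compounds, so an aromatic ring here is not needed to keep it there. Nothing measured here accounts for these numbers. From the compounds shown here alone, whether a carboxylic acid in place of the methoxycarbonyl, or an amine or a longer chain on this nitrogen, would bring a step beyond the scatter stays open.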